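The source may report more compounds than this note shows. Statements on the series, on what has been measured and on what is new or still open speak of the compounds shown alone.

The measured compounds:
compound 1 `CC(C)NC(=O)NC1CC(C)(C)Oc2ccc(Cl)cc21`, 62000 nM in a functional assay on U-373MG ATCC cells (Homo sapiens) for inhibition, read by MTT assay, with a stated time of 72 h; on this read-out higher numbers stand for weaker inhibition and lower numbers for stronger inhibition
compound 2 `CC1(C)CC(NC(=S)Nc2ccc([N+](=O)[O-])cc2)c2cc(Br)ccc2O1`, 9000 nM
compound 3 `CC1(C)CC(NC(=S)Nc2ccccc2Cl)c2cc(Br)ccc2O1`, 34000 nM

Among these three numbers the one of compound 1 is the highest. Compound 3 stands within the scatter of compound 1, so nothing separates the two, while compound 2 lies beyond the scatter with the lower number. Compound 4 `CCNC(=O)NC1CC(C)(C)Oc2ccc(Cl)cc21` has not been measured. It differs from compound 1 in one place: hydrogen in place of methyl on a saturated chain carbon bound to an amide-type nitrogen and a saturated chain carbon. Among the measured compounds shown here, no pair among the measured compounds isolates a change of this kind, so there is no step to lean on. For so small a change at a saturated chain carbon bound to an amide-type nitrogen, one expects in this assay no step beyond the scatter, the estimated step being no change at the digits printed from compound 1 to compound 4 (within the scatter). Compound 4 is therefore expected at 62000 nM, within a range of 25000 nM to 150000 nM.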

Compound 4, half-maximal inhibitory concentration: > 100000 nM
Compound 4 gave a limit, no number (the forecaster's own chance of this, stated with the estimate: 15%); middle value at least 1.6-fold (0.20 log units) away from the limit.
By their numbers in this assay, from the lowest: compound 2; then compounds 3 and 1 (each within the scatter of the next). At a limit, above all of these: compound 4.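

In this assay compound 4 gave > 100000 nM, which is a limit of the assay and not a number. Cutting isopropyl to ethyl gives an at least 1.6-fold higher number from compound 1 to compound 4 (0.20 log units; that floor lies within the scatter), the first step read at this position, and it shows no gain in inhibition from the shorter group. How large the step really is remains unknown: the limit of > 100000 nM in this assay, at which 1 of the 4 values shown sits.

As far as these compounds go, whether a longer chain, such as butyl, or an amine at this place would lower the number stays open. So does whether a carboxylic acid would be tolerated there.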